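This account rests on a few compounds, and the source may have more. Where it says the series, first, only, none or still open, it means among the compounds named here.

Compounds measured so far:
compound 1, `CC(C)(C)N1C[C@@H](C(=O)Nc2nccn2Cc2ccccc2)[C@H](c2ccc(F)cc2F)C1`: 4660 nM
compound 2, `CC(C)(C)N1C[C@@H](C(=O)Nc2nccn2Cc2ccccc2N2CCC(CC(=O)O)CC2)[C@H](c2ccc(F)cc2F)C1`: 1980 nM
compound 3, `CC(C)(C)N1C[C@@H](C(=O)Nc2nccn2Cc2ccccc2-c2ccccc2)[C@H](c2ccc(F)cc2F)C1`: 527 nM

In a functional assay for agonist activity at Melanocyte-stimulating hormone receptor (Homo sapiens), read by cAMP accumulation (a lower number here means that less compound is needed, a higher number that more compound is needed for the effect), compound 3 has the lowest number of the three. Its distance from compound 1 is an 8.8-fold lower number from compound 1 to compound 3 (0.95 log units; beyond the scatter), and from compound 2 it is a 3.8-fold lower number from compound 2 to compound 3 (0.57 log units; beyond the scatter); the two weaker compounds are themselves separated by a 2.4-fold lower number from compound 1 to compound 2 (0.37 log units; beyond the scatter).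

Compound 4, `CC(C)(C)N1C[C@@H](C(=O)Nc2nccn2Cc2ccccc2Cl)[C@H](c2ccc(F)cc2F)C1`, is reached from compound 3 by chloro in place of phenyl on an aromatic carbon. The step from compound 1 to compound 3 is the one that bears most directly on this: there the phenyl entered in place of hydrogen, and the number fell by an 8.8-fold lower number from compound 1 to compound 3 (0.95 log units; beyond the scatter). Compound 4 carries at the same aromatic carbon a group of one heavy atom instead of the six of phenyl, so the account expects the number to move back toward that of compound 1, though not necessarily all the way. Compound 4 is therefore estimated at 2000 nM in this assay, with a range of 700 nM to 6000 nM, a step of a 3.8-fold higher number from compound 3 to compound 4 (0.58 log units; beyond the scatter) that is expected to lie beyond the scatter.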

Compound 4, half-maximal effective concentration: 1270 nM
Compound 4: the middle estimate sits 1.6-fold (0.20 log units) above what was measured; the measured number falls inside the stated range.
By their numbers in this assay, from the lowest: compound 3; then compounds 4 and 2 (each within the scatter of the next); then compound 1.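

In this assay, a single chlorine on this aromatic carbon keeps part of what the phenyl gained, with a 3.7-fold lower number from compound 1 to compound 4 (0.56 log units; beyond the scatter), while the phenyl retains an advantage, seen in a 2.4-fold higher number from compound 3 to compound 4 (0.38 log units; beyond the scatter). Chloro and 4-(carboxymethyl)piperidin-1-yl cannot be ordered at this position, given a 1.6-fold lower number from compound 2 to compound 4 (0.19 log units; within the scatter), so all three groups tried here lower the number relative to hydrogen, and only the phenyl separates from the other two. Nothing available explains why these groups differ or why the two others cannot be separated.

From the compounds shown here alone, whether a methyl, a methoxy or a fluoro on this carbon would match chloro remains open. So does whether a phenyl carrying a carboxylic acid or an amine would keep the number of compound 3 527 nM.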